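This account rests on a few compounds, and the source may have more. Where it says the series, first, only, none or still open, it means among the compounds named here.

Compound 1 `CC(C)(C)OC(=O)N1CCC(Oc2cc(Oc3ccc(/C=C4\SC(=O)NC4=O)cc3)ncn2)CC1` gives 122%.
Compound 2 `O=C1NC(=O)/C(=C/c2ccc(Oc3cc(OC4CCN(C(=O)OCc5ccccc5)CC4)ncn3)cc2)S1` gives 88.3%.
Compound 3 `COC(=O)N1CCC(Oc2cc(Oc3cccc(/C=C4\SC(=O)NC4=O)c3)ncn2)CC1` gives 33.7%.

All three were tested in a functional assay on CHO-K1 cells for agonist activity at Glucose-dependent insulinotropic receptor (Homo sapiens), read by cAMP accumulation and immunoassay, with a stated time of 1 h; on this read-out lower numbers stand for smaller maximal responses and higher numbers for larger maximal responses. Among these numbers compound 3 stands lowest, and its distance to both compound 2 and compound 1 lies beyond the scatter, so it gives the smallest response of the three.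

Compound 4 `CC(C)(C)OC(=O)N1CCC(Oc2cc(Oc3cccc(/C=C4\SC(=O)NC4=O)c3)ncn2)CC1` differs from compound 3 in one place: tert-butyl in place of methyl on an oxygen next to a carbonyl group. Among the compounds with values here, only one measured step touches the group on this oxygen, the step of a number 33.7 percentage points lower from compound 1 to compound 2 (beyond the scatter), where benzyl in place of tert-butyl on an oxygen next to a carbonyl group brought a large fall. That step compares tert-butyl with benzyl, not with methyl, and it was measured on a core that is not the same as the shared core of compound 3 and compound 4, so it bears on the new step only loosely. Still, tert-butyl on this oxygen went with the largest response seen here, in compound 1, and methyl with the smallest, in compound 3, so a rise is expected, of uncertain size.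

For compound 4 the expected value is 58%, within 30% to 95%, which means an expected step of a number 24.3 percentage points higher from compound 3 to compound 4 (beyond the scatter).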

Compound 4, largest response reached (Emax), in percent of the reference or control that the assay uses: 78.3%
The estimate for compound 4 lay 20.3 percentage points below the measured number, within the range that was stated.
By their numbers in this assay, from the lowest: compound 3; then compounds 4 and 2 (each within the scatter of the next); then compound 1.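

Within the data shown here, exchanging methyl for tert-butyl on an oxygen next to a carbonyl group brings a number 44.6 percentage points higher from compound 3 to compound 4 (beyond the scatter) in this assay, and this is the first direct measure of that change, since the earlier step compared benzyl with tert-butyl on the core of compound 1. Methyl, with 1 heavy atom, gives way to tert-butyl, with 4 heavy atoms, and neither group has a ring, a hydrogen-bond donor or a hydrogen-bond acceptor, so a change made only of carbon and its hydrogens is enough at this place to produce a large step in the maximal response. Nothing measured here explains why the response rises with this change.

The compounds shown leave open where an ethyl or isopropyl group on this oxygen would fall, and whether a free amine in place of the whole tert-butoxycarbonyl would keep any response. Also open, as far as these compounds go, is whether methyl in place of tert-butyl on the core of compound 1 would bring a step of similar size.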